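Amide side chain variation in a paw edema model

The compounds below may be only part of what the source reports. "The series", "measured", "known", "first", "only" and "open" are said of these compounds alone.

Measured compounds:
compound 1 `COc1cc2c(cc1OC)C(CC(=O)N(C)C)CC2`: 25%
compound 2 `CCCCNC(=O)CC1CCc2cc(OC)c(OC)cc21`: 31.3%
compound 3 `COc1cc2c(cc1OC)C(CC(=O)NCc1ccccc1)CC2`: 18.8%

In a functional assay on the whole organism (strain Wistar) for inhibition, with Rattus norvegicus as the target, read by paw edema, with stated times of 60 min and 1 h, at a dose of 100 mg/kg by the oral route (on this read-out higher numbers stand for more inhibition at the one dose given (going by the name of the read-out) and lower numbers for less inhibition), compound 3 gives the lowest of the three numbers; its nearest neighbour is compound 1, whose value sits within the scatter of it, while the gap to compound 2 lies beyond the scatter, as a number 12.5 percentage points lower from compound 2 to compound 3 (beyond the scatter) shows. Compound 4 `COc1cc2c(cc1OC)C(CC(=O)NCCO)CC2` differs from compound 3 by the change (hydroxymethyl in place of phenyl on a saturated chain carbon bound to an amide-type nitrogen). Within the data shown here, two measured steps bear on the amide substituent: a number 6.3 percentage points higher from compound 1 to compound 2 (within the scatter) and a number 6.2 percentage points lower from compound 1 to compound 3 (within the scatter) were both within the scatter, and only a number 12.5 percentage points lower from compound 2 to compound 3 (beyond the scatter) was a modest step. Among the measured compounds shown here, no measured compound carries a hydroxyl on this chain, so the direction is uncertain; a small rise toward the other two values is expected, a number 5.2 percentage points higher from compound 3 to compound 4 (within the scatter). Compound 4 is therefore estimated at 24%, between 10% and 38%.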

Compound 4, a percentage reported as inhibition, in the whole organism at one dose (the size of the read-out at that dose, not a potency): 0%
Compound 4: the middle estimate sits 24 percentage points above what was measured, outside the stated range (below it).
By their numbers in this assay, from the lowest: compound 4; then compounds 3, 1 and 2 (each within the scatter of the next, the first and the last beyond it).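

In this assay, the change to (2-hydroxyethyl)amino shows up as a number 18.8 percentage points lower from compound 3 to compound 4 (beyond the scatter), as a number 31.3 percentage points lower from compound 2 to compound 4 (beyond the scatter) and as a number 25 percentage points lower from compound 1 to compound 4 (beyond the scatter). Earlier changes at this position left at least one neighbour within the scatter, whereas compound 4, at 0%, stands apart from all three other compounds, so this amide substituent can decide whether any inhibition is seen at this dose. Nothing available explains this loss. From the compounds shown here alone, it remains open whether the hydroxy group itself is responsible. Placing a methoxy group or an amine on the same chain, or a hydroxy group on a longer chain, would test this.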